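Benzoyl to tert-Butylcarbamoyl: Permeability of Compound 3

The compounds below may be only part of what the source reports. "The series", "measured", "known", "first", "only" and "open" are said of these compounds alone.

Measured compounds:
compound 1 `Cn1cncc1CN1CC(N(CC2CCN(C(=O)c3ccccc3)CC2)S(=O)(=O)c2ccccn2)Cc2cc(C#N)ccc21`: 0.5 10^-6 cm/s
compound 2 `CCCC(=O)N1CCC(CN(C2Cc3cc(C#N)ccc3N(Cc3cncn3C)C2)S(=O)(=O)c2ccccn2)CC1`: 0.5 10^-6 cm/s

In an ADME assay on Caco-2 cells (Homo sapiens) for permeability, in the apical to basolateral direction (on this read-out lower numbers stand for lower permeability and higher numbers for higher permeability), compound 1 gives 0.5 10^-6 cm/s. Going by the values given here, it stands level with compound 2, which in this assay gives 0.5 10^-6 cm/s; the one measured step, propyl in place of phenyl on a carbonyl carbon, reads no change at the digits printed from compound 1 to compound 2 (within the scatter), so the two values sit together within the scatter.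

Compound 3 `Cn1cncc1CN1CC(N(CC2CCN(C(=O)NC(C)(C)C)CC2)S(=O)(=O)c2ccccn2)Cc2cc(C#N)ccc21` has not yet been measured in this assay. It differs from compound 1 in one place: (tert-butyl)amino in place of phenyl on a carbonyl carbon. The change sits on the same carbonyl carbon as the measured step, but where that step exchanged one group without donors for another, this one brings in a hydrogen-bond donor, as counted above. The step from compound 1 to compound 2 is the only one that bears on it, and it was flat. On that basis a step of no more than the scatter is expected, leaning slightly downward, written as a 1.3-fold lower number from compound 1 to compound 3 (0.10 log units; within the scatter). Compound 3 is therefore estimated at 0.4 10^-6 cm/s, within a range from 0.15 10^-6 cm/s to 1 10^-6 cm/s.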

Compound 3, apparent permeability: 0.6 10^-6 cm/s
For compound 3 the middle estimate is 1.5-fold (0.18 log units) below the measured one; measured number inside the range.
By their numbers in this assay, from the lowest: compounds 1, 2 and 3 (each within the scatter of the next).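

In this assay, (tert-butyl)amino in place of phenyl, on a carbonyl carbon whose other neighbours are amide-type nitrogen in a ring, reads (a 1.2-fold higher number from compound 1 to compound 3 (0.08 log units; within the scatter)), and the same group in place of propyl reads (a 1.2-fold higher number from compound 2 to compound 3 (0.08 log units; within the scatter)). Going by these compounds alone, the earlier pair compared only two groups without a hydrogen-bond donor, whereas compound 3 carries one in the group that enters, and the read-out at this place still stays within the scatter across phenyl, propyl and (tert-butyl)amino. Nothing available gives a measured property of these groups that would account for this reading.

The three compounds leave open whether any group on this carbonyl carbon can move the read-out beyond the scatter, for instance a carboxylic acid, a basic amine or a longer chain. They also leave open whether the same flat reading would hold if the pyridine-free parts of the molecule stayed fixed only in part, that is, if the core of compound 1 were changed elsewhere at the same time.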